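From a Difluorophenyl to an Aminophenyl Side Ring

This account rests on a few compounds, and the source may have more. Where it says the series, first, only, none or still open, it means among the compounds named here.

Of the compounds shown here, two built on a shared core have so far been tested in a functional assay on HL-60 cells (Homo sapiens) for cytotoxicity, read by CellTiter-Blue, with a stated time of 48 h; a higher number here means a weaker inhibitor, a lower number a stronger inhibitor. Compound 1 `CCOC(=O)CC1C(C(=O)OC)=C(N)Oc2ccc(-c3cc(OC)cc(OC)c3)cc21` gives 10800 nM. Compound 2 `CCOC(=O)CC1C(C(=O)OCC)=C(N)Oc2ccc(-c3ccc(F)cc3F)cc21` gives 76600 nM, the highest of the two numbers, and its gap to compound 1 lies beyond the usual scatter of repeated measurements, so compound 2 is the weaker inhibitor of the pair. Compound 3 `CCOC(=O)CC1C(C(=O)OCC)=C(N)Oc2ccc(-c3cccc(N)c3)cc21` has not yet been measured in this assay. It differs from compound 2 in one place: 3-aminophenyl in place of 2,4-difluorophenyl on an aromatic carbon. Among the measured compounds shown here, no measured pair differing in a single place exists here, so the effect of this change cannot be read from a measured step, and the expectation rests on the two numbers alone. The step expected is a 2.6-fold lower number from compound 2 to compound 3 (0.41 log units; beyond the scatter), a fall toward a lower number that goes beyond the scatter. Compound 3 is estimated to give about 30000 nM, with a likely range from 8000 nM to 120000 nM.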

Compound 3, half-maximal inhibitory concentration: 20200 nM
Estimate against measurement, compound 3: 1.5-fold (0.17 log units) above, and the stated range covers the measured number.
By their numbers in this assay, from the lowest: compounds 1 and 3 (each within the scatter of the next); then compound 2.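

In this assay, among the compounds shown here, setting 3-aminophenyl in place of 2,4-difluorophenyl gives a 3.8-fold lower number from compound 2 to compound 3 (0.58 log units; beyond the scatter) as the first step that can be read at a single place, and although modest, it lies beyond the scatter. It shows that the number responds to the identity of this side ring while the rest of the structure stays unchanged. Nothing available explains why this exchange lowers the number.

The change removes both fluorines and introduces the amine at once, so the two compounds do not show whether either alteration alone accounts for the step. On these data alone, it remains open how a plain phenyl ring would compare, or whether a hydroxyl group or an acetamide in the amine's place would give a similar number.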